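Furyl-to-chlorofuryl swap on a pyridine triaryl series

A few compounds are considered here, and "the series" means these few. Any claim that something is new, unique, unknown or untested is made for them only; others in the source may bear on it.

In a functional assay on K562 cells (Homo sapiens) for cytotoxicity, in the presence of a further agent that is not named here (on this read-out lower numbers stand for stronger inhibition and higher numbers for weaker inhibition), compound 1 `Clc1ccc(-c2cc(-c3cccnc3)nc(-c3cccs3)c2)o1` gives 22300 nM, compound 2 `Clc1ccc(-c2cc(-c3ccc(Cl)o3)cc(-c3ccsc3)n2)cc1` gives 18700 nM, and compound 3 `Clc1ccc(-c2cc(-c3ccoc3)cc(-c3cccs3)n2)cc1` gives 21100 nM. Within this set the number of compound 3 lies within the scatter of both compound 1 and compound 2, so the three cannot be ordered against each other on this assay.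

Compound 4 `Clc1ccc(-c2cc(-c3ccc(Cl)o3)cc(-c3cccs3)n2)cc1` differs from compound 3 by one change: 5-chlorofuran-2-yl in place of furan-3-yl on an aromatic carbon. For the measured compounds named here, no measured pair shows this exact exchange. The step from compound 3 to compound 4 is expected to stay within the scatter, since compound 2 gives 18700 nM while carrying the same 5-chlorofuran-2-yl group. Compound 4 is therefore estimated at 19000 nM, with a range of 9000 nM to 40000 nM, corresponding to an expected step of a 1.1-fold lower number from compound 3 to compound 4 (0.05 log units; within the scatter).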

Compound 4, half-maximal inhibitory concentration: 20900 nM
Estimate against measurement, compound 4: 1.1-fold (0.04 log units) below; the measured number falls inside the stated range.
By their numbers in this assay, from the lowest: compounds 2, 4, 3 and 1 (each within the scatter of the next).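

In this assay the exchange of furan-3-yl for 5-chlorofuran-2-yl opposite the ring nitrogen gives a 1.0-fold lower number from compound 3 to compound 4 (0.00 log units; within the scatter) with the rest of the structure unchanged. Thiophen-2-yl in place of thiophen-3-yl gives a 1.1-fold higher number from compound 2 to compound 4 (0.05 log units; within the scatter) and 4-chlorophenyl in place of pyridin-3-yl gives a 1.1-fold lower number from compound 1 to compound 4 (0.03 log units; within the scatter) as well, so all three single exchanges that lead to compound 4 stay within the scatter. From the compounds shown here alone, whether any group at the position opposite the ring nitrogen moves the number beyond the scatter stays open, for instance an amine or a carboxylic acid in place of 5-chlorofuran-2-yl. No measured evidence accompanies these numbers to account for them.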